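Sulfonyl chain variation on a cyclohexyl dichlorobenzamide series

The compounds below may be only part of what the source reports. "The series", "measured", "known", "first", "only" and "open" are said of these compounds alone.

Measured so far:
compound 1, `CCS(=O)(=O)[C@H]1CC[C@@](CNC(=O)c2ccc(Cl)cc2Cl)(CC2CC2)CC1` — 1320 nM
compound 2, `CCCS(=O)(=O)[C@H]1CC[C@](CNC(=O)c2ccc(Cl)cc2Cl)(CC2CC2)CC1` — 36.9 nM

In an assay on isolated protein for inhibition of sodium- and chloride-dependent glycine transporter 1 (Homo sapiens), with a stated time of 15 min (a higher number here means a weaker inhibitor, a lower number a stronger inhibitor), compound 1 gives 1320 nM, while compound 2 gives 36.9 nM. Compound 2 thus stands at the lowest of the two numbers, and the gap to compound 1 lies well beyond the scatter. Among the compounds with values here, compound 1 and compound 2 differ in more than one place, so no single step is read from that pair.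

The next compound, compound 3, `O=C(NC[C@]1(CC2CC2)CC[C@H](S(=O)(=O)CC2CC2)CC1)c1ccc(Cl)cc1Cl`, is to be measured in this assay. It differs from compound 2 by one change: cyclopropyl in place of ethyl on a saturated chain carbon bound to a sulfonyl sulfur. The sulfonyl substituent keeps its length by atom count and gains a ring, with no change in donors, acceptors or charge.

Within the data shown here, with no comparable step among the measured compounds, the expectation is a step from compound 2 to compound 3 of about a 1.2-fold lower number from compound 2 to compound 3 (0.09 log units; within the scatter), within or close to the scatter. For compound 3 the estimate in this assay is 30 nM, expected to fall between 10 nM and 100 nM.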

Compound 3, half-maximal inhibitory concentration: 29 nM
Compound 3: the middle estimate sits 1.0-fold (0.01 log units) above what was measured; the range from low to high includes it.
By their numbers in this assay, from the lowest: compounds 3 and 2 (each within the scatter of the next); then compound 1.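

In this assay, cyclopropyl in place of ethyl on a saturated chain carbon bound to a sulfonyl sulfur gives a 1.3-fold lower number from compound 2 to compound 3 (0.10 log units; within the scatter), so the two groups cannot be told apart at this place. Within the data shown here, this is the first single-change step, and it shows that the sulfonyl substituent can carry a three-membered carbon ring in place of an open chain with no difference beyond the scatter. Nothing at hand bears on why propylsulfonyl and (cyclopropylmethyl)sulfonyl read alike.

Compound 1 and compound 2 differ in more than one place, so the size of the sulfonyl chain cannot be read from that pair. Going by these compounds, how far this tolerance extends remains open, for instance to a longer chain such as butyl, to a phenyl ring or to an amine on the sulfonyl substituent.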